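Cytotoxicity of a macrocyclic series: swapping isopropyl for ethynyl

The source may report more compounds than this note shows. Statements on the series, on what has been measured and on what is new or still open speak of the compounds shown alone.

Measured so far:
Compound 1 `COc1ccc2c(O[C@H]3C[C@H]4C(=O)N(C)CCCC/C=C/[C@@H]5C[C@@]5(C(=O)NS(=O)(=O)C5(C)CC5)NC(=O)N4C3)cc(-c3nc(C(C)C)cs3)nc2c1Cl`: 48500 nM
Compound 2 `COc1ccc2c(O[C@H]3C[C@H]4C(=O)N(C)CCCC/C=C/[C@@H]5C[C@@]5(C(=O)NS(=O)(=O)C5(C)CC5)NC(=O)N4C3)cc(-c3nc(C(C)C)cs3)nc2c1Br`: 51200 nM
Compound 3 `COc1ccc2c(O[C@H]3C[C@H]4C(=O)N(C)CCCC/C=C/[C@@H]5C[C@@]5(C(=O)NS(=O)(=O)C5(C)CC5)NC(=O)N4C3)cc(C#N)nc2c1C`: 55800 nM

In an ADME assay on Huh-7 cells (Homo sapiens) for cytotoxicity, read by colorimetric assay (a higher number here means that more compound is tolerated, a lower number that less compound is tolerated), compound 1 gives 48500 nM. Its nearest neighbour is compound 2, and the step of a 1.1-fold higher number from compound 1 to compound 2 (0.02 log units; within the scatter) tells that the two numbers cannot be told apart. Within the data shown here, compound 3 differs from compound 1 at two places at once, so no single step is drawn between them; in this assay compound 3 gives 55800 nM, and its gap from compound 1 is likewise within the scatter. All three numbers therefore sit together with no separation that the assay can resolve.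

Compound 4 `C#Cc1csc(-c2cc(O[C@H]3C[C@H]4C(=O)N(C)CCCC/C=C/[C@@H]5C[C@@]5(C(=O)NS(=O)(=O)C5(C)CC5)NC(=O)N4C3)c3ccc(OC)c(Cl)c3n2)n1` is the unmeasured compound. It differs from compound 1 in one place: ethynyl in place of isopropyl on an aromatic carbon.

Among the measured compounds shown here, none of the measured steps touches the thiazole substituent; the only step, the halogen swap from compound 1 to compound 2, lies elsewhere and is within the scatter. For the measured compounds named here, with no direct precedent, and with the three measured compounds giving indistinguishable tolerance despite different substituents, the change in this assay is expected to stay within the scatter, as a 1.0-fold higher number from compound 1 to compound 4 (0.01 log units; within the scatter) expresses. Compound 4 is therefore estimated at 50000 nM, with a range from 25000 nM to 100000 nM.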

Compound 4, half-maximal cytotoxic concentration: 17000 nM
Compound 4: middle estimate off by 2.9-fold (0.47 log units), on the high side, outside the stated range (below it).
By their numbers in this assay, from the lowest: compound 4; then compounds 1, 2 and 3 (each within the scatter of the next).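

In this assay, the change from 4-isopropyl-1,3-thiazol-2-yl to 4-ethynyl-1,3-thiazol-2-yl gives a 2.9-fold lower number from compound 1 to compound 4 (0.46 log units; beyond the scatter), the only step shown here that lies beyond the scatter. The group on this carbon, next to the ring nitrogen, therefore has a modest effect on how much compound the cells tolerate, unlike the halogen swap, which gives a 1.1-fold higher number from compound 1 to compound 2 (0.02 log units; within the scatter). No measurement available here explains why the number falls.

An ethyl group at this position would help show whether the triple bond matters or whether any group other than isopropyl would give a similar result. On these data alone, it also remains open whether ethynyl would give a similar step on the bromo-bearing core of compound 2.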